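Swapping a Ring for an Amide on an Acid Core

The source may hold more compounds than are shown below. What is called first, only, known or untested is meant among the compounds shown, and "the series" means these compounds.

Of the compounds shown here, three have been measured in an assay for inhibition of inositol hexakisphosphate kinase 2 (Homo sapiens), read by colorimetric assay, coupled enzyme assay and malachite green, with a stated time of 120 min, in the presence of a further agent that is not named here; a higher number here means a weaker inhibitor, a lower number a stronger inhibitor. Compound 1 `CNC(=O)/C=C/c1ccc2noc(-c3ccccc3)c2c1` gives 58200 nM in this assay. Compound 2 `Cc1cccc(-c2onc3ccc(/C=C/C(=O)O)cc23)c1` gives 290 nM, and compound 3 `O=C(O)c1ccc2noc(-c3ccc(N4CCCCC4)cc3)c2c1` gives 240 nM. Compound 3 sits at the low end of these three numbers: compound 2 lies within the usual scatter of it, while compound 1 lies far higher, beyond the scatter.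

The next step leads from compound 3 to compound 4 `CC(C)NC(=O)c1ccc(-c2onc3ccc(C(=O)O)cc23)cc1`, which has not yet been measured in this assay. The change is isopropylcarbamoyl in place of piperidin-1-yl on an aromatic carbon. The rest of the molecule, including the carboxylic acid on the shared core, is unchanged.

Among the compounds with values here, no measured pair shows this particular exchange, so the expectation rests on the wider picture. Within the data shown here, compound 4 keeps the carboxylic acid that compound 2 and compound 3 carry, and the one compound without it, compound 1, gives 58200 nM in this assay, so compound 4 is expected to stay in the range of the two acids, with a step from compound 3 estimated at a 2.1-fold higher number from compound 3 to compound 4 (0.32 log units; beyond the scatter), modestly weaker but not far outside the scatter. The value expected for compound 4 in this assay is 500 nM, with a likely range from 150 nM to 2000 nM.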

Compound 4, half-maximal inhibitory concentration: 350 nM
Compound 4: middle estimate off by 1.4-fold (0.15 log units), on the high side, within the range that was stated.
By their numbers in this assay, from the lowest: compounds 3, 2 and 4 (each within the scatter of the next); then compound 1.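

In this assay, placing isopropylcarbamoyl in place of piperidin-1-yl on this aromatic carbon, para to a large group, gives a 1.5-fold higher number from compound 3 to compound 4 (0.16 log units; within the scatter), so the two compounds cannot be told apart in this assay. Within the data shown here, this is the first measured pair to differ at this position, and it shows that the number holds when a six-membered non-aromatic ring with no hydrogen-bond donor is exchanged for an open group with no ring, a carbonyl and an amide hydrogen. Nothing available here explains why these two different groups give such similar readings.

The compounds shown leave open what a morpholine ring, a carboxylic acid or a plain hydrogen would give on this same aromatic carbon, and whether a longer chain in place of the isopropyl on the amide nitrogen would keep the number where it is. They also leave open whether the amide hydrogen matters at all, a question that a dimethylcarbamoyl group, which lacks that hydrogen, could address.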